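Pyridinyl to fluorophenyl on a triazole: two cores compared

A few compounds are considered here, and "the series" means these few. Any claim that something is new, unique, unknown or untested is made for them only; others in the source may bear on it.

Measured compounds:
compound 1 `CCOC(=O)c1sc(NC(=O)Cn2cc(-c3ccc(F)cc3)nn2)nc1C` — 660 nM
compound 2 `O=C(Cn1cc(-c2ccncc2)nn1)Nc1nc2ccccc2s1` — 50 nM
compound 3 `CCOC(=O)c1sc(NC(=O)Cn2cc(-c3ccncc3)nn2)nc1C` — 120 nM

In a functional assay on BMDM cells (Mus musculus, strain C57BL/6) for inhibition, with a stated time of 2 days (on this read-out higher numbers stand for weaker inhibition and lower numbers for stronger inhibition), compound 2 gives the lowest of the three values, with compound 3 the nearest to it and compound 1 the furthest. How the core of compound 2 differs from the core of compound 3 is not broken down here.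

Between compound 3 and compound 1 one change is made, (4-fluorophenyl in place of pyridin-4-yl on an aromatic carbon), and it produced a 5.5-fold higher number from compound 3 to compound 1 (0.74 log units; beyond the scatter). Compound 4 `O=C(Cn1cc(-c2ccc(F)cc2)nn1)Nc1nc2ccccc2s1` has not yet been measured in this assay. It stands to compound 2 exactly as compound 1 stands to compound 3: the difference is 4-fluorophenyl in place of pyridin-4-yl on an aromatic carbon, and the place lines of the two changes read the same word for word, so this is the same change carried onto the core of compound 2.

Resting on the single measured step from compound 3 to compound 1, compound 4 is expected to give a step of a 5.0-fold higher number from compound 2 to compound 4 (0.70 log units; beyond the scatter) from compound 2. For the measured compounds named here, for compound 4 the estimate in this assay is 250 nM, with a range from 100 nM to 700 nM, because the only guide is the step of a 5.5-fold higher number from compound 3 to compound 1 (0.74 log units; beyond the scatter) seen on a different core.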

Compound 4, half-maximal inhibitory concentration: > 30000 nM
Compound 4: a limit, no number; the forecaster's own chance of this, stated with the estimate: 3%; at least 120-fold (2.07 log units) between middle value and limit.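

In this assay compound 4 gives > 30000 nM, which is a limit of the assay and not a number. Replacing pyridin-4-yl with 4-fluorophenyl on the core of compound 2 gives an at least 600-fold higher number from compound 2 to compound 4 (2.77 log units; beyond the scatter), so the size of the step seen on the other core did not carry over: the same change on two cores in this assay, a 5.5-fold higher number (0.74 log units; beyond the scatter) from compound 3 to compound 1 and an at least 600-fold higher number (2.77 log units; beyond the scatter) from compound 2 to compound 4, at least 100-fold (2.03 log units) apart, beyond the scatter of two such steps. The two cores agree in direction, with the 4-fluorophenyl compound giving the higher number on each, but the true size of the step on the core of compound 2 remains unknown, and a single pair on each core neither explains the gap nor sets a rule for other cores.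

The compounds shown leave open how a plain phenyl group would behave on the same aromatic carbon of either core, which would separate the loss of the ring nitrogen from the entry of the fluorine. They also leave open whether a carboxylic acid in place of the ethyl ester of compound 3 would alter the size of the step.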